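A few compounds are considered here, and "the series" means these few. Any claim that something is new, unique, unknown or untested is made for them only; others in the source may bear on it.

Measured in a functional assay on KOPN-8 cells (Homo sapiens) for antiproliferative activity, with a stated time of 72 h; on this read-out lower numbers stand for an effect already at smaller amounts and higher numbers for an effect only at larger amounts of compound:
Compound 1 `COc1ccc(-c2c(Cl)c(=O)c3c(OC)cc(OC)cc3n2S(=O)(=O)c2ccc(OC)cc2)cc1` gives 19100 nM.
Compound 2 `COC(=O)c1cc(=O)c2c(OC)cc(OC)cc2[nH]1` gives > 34400 nM.
Compound 3 `COc1ccc(-c2cc(=O)c3c(OC)cc(OC)cc3n2S(=O)(=O)c2ccc([N+](=O)[O-])cc2)cc1` gives 17300 nM.

Compound 3 holds the lowest of the two numbers shown, yet compound 1 sits within the scatter of it, so no order between the two can be read. The figure for compound 2 is the limit of > 34400 nM in this assay, at which 1 of the 3 values shown sits, and not a number. Compound 4 `COc1ccc(-c2cc(=O)c3c(OC)cc(OC)cc3n2S(=O)(=O)Cc2ccccc2)cc1` is not yet measured; it differs from compound 3 by benzyl in place of 4-nitrophenyl on a sulfonyl sulfur. Among the compounds with values here, no measured step isolates the group on the sulfonyl sulfur. Compound 1 and compound 3, which differ there among other places, sit within the scatter of each other, so the step of a 1.2-fold higher number from compound 3 to compound 4 (0.06 log units; within the scatter) is expected to stay within the scatter, with no clear direction. Compound 4 is estimated at 20000 nM, between 8000 nM and 50000 nM.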

Compound 4, half-maximal effective concentration: > 34400 nM
Compound 4 ended at the assay's limit; the forecaster's own chance of this, stated with the estimate: 25%; middle value at least 1.7-fold (0.23 log units) away from the limit.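

In this assay, within the data shown here, benzyl in place of 4-nitrophenyl on a sulfonyl sulfur gives an at least 1.9-fold higher number from compound 3 to compound 4 (0.29 log units; that floor lies within the scatter) as the first one-place step at this position. Since that floor lies within the scatter, the change cannot be called a clear loss, although it brought no lower number. Compound 4 stands at a limit and not at a number, a place it shares with one other compound: the limit of > 34400 nM in this assay, at which 2 of the 4 values shown sit.

On these data alone, how far compound 4 lies past that limit stays open. So does the effect of an amine or a carboxylic acid on the phenyl ring at this sulfonyl sulfur.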